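Swapping an oxygen ring for a sulfur ring on a sulfonyl-linked arm

The source may report more compounds than this note shows. Statements on the series, on what has been measured and on what is new or still open speak of the compounds shown alone.

Measured compounds:
compound 1 `O=S(=O)(CC1=NCCO1)c1n[nH]cc1-c1ccc(Cl)cc1`: "not active" (no number reported)
compound 2 `O=S(=O)(CC1=NCCO1)c1n[nH]cc1-c1ccccc1`: 58.5%
compound 3 `Cc1ccc(C2CNN=C2S(=O)(=O)CC2=NCCS2)cc1`: 45.1%

In a functional assay, tested at 100 ug/mL (a higher number here means a stronger effect of the compound at the concentration tested, a lower number a weaker effect), compound 1 was reported as "not active" (no number reported), so it carries no number and stands at the bottom of the three. Compound 2 gives 58.5% and compound 3 gives 45.1% in this assay. Compound 4 `O=S(=O)(CC1=NCCS1)c1n[nH]cc1-c1ccc(Cl)cc1` has not been measured. It differs from compound 1 by a group of 5 heavy atoms (3 carbon, 1 nitrogen, 1 sulfur; one five-membered non-aromatic ring with 2 hetero atoms) in place of a group of 5 heavy atoms (3 carbon, 1 nitrogen, 1 oxygen; one five-membered non-aromatic ring with 2 hetero atoms), on a saturated chain carbon bound to a sulfonyl sulfur. Within the data shown here, no measured pair shows this exact change, so its size is unknown; a move upward from compound 1 is possible, and a modest gain beyond the scatter would not be surprising, but a result that stays inactive is equally plausible. Compound 4 is expected to reach about 20%, within a range from 0% to 50%.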

Compound 4, a percentage reported as activity, at one concentration (the size of the read-out at that concentration, not a potency): "not active" (no number reported)
The entry for compound 4 holds no number; no gap can be computed for the estimate.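

In this assay compound 1 gives "not active" (no number reported) and compound 4 gives "not active" (no number reported), so no step can be read for this ring swap, and nothing available explains the result. Left open is whether the swap changes the read-out in a compound that gives a number.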